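Shrinking a Ring on a Methyl-Bearing Core

The source may report more compounds than this note shows. Statements on the series, on what has been measured and on what is new or still open speak of the compounds shown alone.

Of the compounds shown here, three have been measured in a functional assay on MCF7 cells (Homo sapiens) for cytotoxicity, read by MTT assay, with a stated time of 72 h; a higher number here means a weaker inhibitor, a lower number a stronger inhibitor. Compound 1 `N/C(=N\NC(=S)N1CCCCC1)c1ccccn1` gives 8500 nM in this assay. Compound 2 `N/C(=N\NC(=S)N1CCCC1)c1ccccn1` carries pyrrolidin-1-yl in place of piperidin-1-yl on a thiocarbonyl carbon; in this assay compound 2 gives 3600 nM, and the step is a 2.4-fold lower number from compound 1 to compound 2 (0.37 log units; beyond the scatter). Compound 3 `Cc1ccnc(/C(N)=N/NC(=S)N2CCCCC2)c1` gives 18800 nM in this assay, the highest number of the three; the step is a 2.2-fold higher number from compound 1 to compound 3 (0.34 log units; beyond the scatter), and its distance from compound 2 is also beyond the scatter, so compound 3 is the weakest inhibitor measured here.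

Compound 4 `Cc1ccnc(/C(N)=N/NC(=S)N2CCCC2)c1` is not yet measured. It relates to compound 3 as compound 2 relates to compound 1: the change is pyrrolidin-1-yl in place of piperidin-1-yl on a thiocarbonyl carbon, and the place is the same word for word. The two cores differ by methyl in place of hydrogen on an aromatic carbon, so the same change is now tried on a methyl-bearing core. Among the compounds shown this ring change occurs twice in all, and only one instance has a measured outcome.

Within the data shown here, for compound 4 the expected step is a 2.4-fold lower number from compound 3 to compound 4 (0.38 log units; beyond the scatter), because a 2.4-fold lower number from compound 1 to compound 2 (0.37 log units; beyond the scatter) shows what this change did on the other core, and no measured pair shows it behaving differently. With that single precedent the range is kept wide. Compound 4 is estimated at 7800 nM in this assay, with a likely range from 4000 nM to 16000 nM.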

Compound 4, half-maximal inhibitory concentration: 1200 nM
Compound 4: the middle estimate sits 6.5-fold (0.81 log units) above what was measured, outside the stated range (below it).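

In this assay the swap of piperidin-1-yl for pyrrolidin-1-yl on the methyl-bearing core gives a 16-fold lower number from compound 3 to compound 4 (1.19 log units; beyond the scatter) and so keeps the direction seen on the other core, but the size does not carry over: the same change on two cores in this assay, a 2.4-fold lower number (0.37 log units; beyond the scatter) from compound 1 to compound 2 and a 16-fold lower number (1.19 log units; beyond the scatter) from compound 3 to compound 4, 6.6-fold (0.82 log units) apart, beyond the scatter of two such steps. The methyl group does not add a fixed amount either: with pyrrolidin-1-yl in place it gives a 3.0-fold lower number from compound 2 to compound 4 (0.48 log units; beyond the scatter) and so runs opposite to its step with piperidin-1-yl: the same change on two cores in this assay, a 2.2-fold higher number (0.34 log units; beyond the scatter) from compound 1 to compound 3 and a 3.0-fold lower number (0.48 log units; beyond the scatter) from compound 2 to compound 4, 6.6-fold (0.82 log units) apart, beyond the scatter of two such steps. Together these results show that, in these four compounds, the effect of each change depends on the other, so adding up separate steps would have missed the value of compound 4, but a single set of four compounds shows neither why this happens nor that it holds anywhere else in the series.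

The compounds shown leave open whether the stronger effect on the methyl-bearing core extends to other rings on the thiocarbonyl carbon, such as azepan-1-yl or morpholin-4-yl. They also leave open whether a different group on the aromatic carbon, such as ethyl, chloro or methoxy, would strengthen the effect of the ring change as methyl does here.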